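The source may report more compounds than this note shows. Statements on the series, on what has been measured and on what is new or still open speak of the compounds shown alone.

Measured so far:
Compound 1, `O=C(c1ccc(F)cc1)N1CCc2nc(COc3ccccc3F)oc2C1`, gives 78%
Compound 2, `O=C(c1ccc(F)cc1)N1CCc2nc(COc3ccc(F)cc3)oc2C1`, gives 73%

In a functional assay on HEK293 cells for positive allosteric modulation of metabotropic glutamate receptor 5 (Homo sapiens), read by calcium flux (on this read-out lower numbers stand for smaller maximal responses and higher numbers for larger maximal responses), compound 2 holds the lower of the two numbers, with compound 1 nearest; the step of a number 5 percentage points lower from compound 1 to compound 2 (within the scatter) lies within the scatter, so the two cannot be told apart. Compound 3 is `O=C(c1ccc(F)cc1)N1CCc2nc(COc3cccnc3)oc2C1` and has not yet been measured. It differs from compound 2 in one place: pyridin-3-yl in place of 4-fluorophenyl on an oxygen on a saturated carbon. Within the data shown here, the only measured step, a number 5 percentage points lower from compound 1 to compound 2 (within the scatter), exchanged one fluorophenyl for another on the same oxygen and stayed within the scatter. Among the measured compounds shown here, no measured pair replaces that ring with pyridin-3-yl, so there is no direct guide for this change. For the measured compounds named here, compound 3 is therefore expected to give a maximal response close to that of compound 2, because the one comparable step a number 5 percentage points lower from compound 1 to compound 2 (within the scatter) was small. The estimated step is a number 3 percentage points lower from compound 2 to compound 3 (within the scatter), not beyond the scatter. The estimate for compound 3 in this assay is 70%, with a range from 50% to 90%.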

Compound 3, largest response reached (reported as percent of maximum), in percent of the reference or control that the assay uses: 40%
Beside the measured number, compound 3's estimate is 30 percentage points above it; the measured number lies below the stated range.
By their numbers in this assay, from the lowest: compound 3; then compounds 2 and 1 (each within the scatter of the next).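

In this assay, among these compounds, the group on the oxygen turns out to matter far more than the earlier compounds suggested: exchanging one fluorophenyl for another stayed within the scatter, whereas pyridin-3-yl in place of 4-fluorophenyl brings a number 33 percentage points lower from compound 2 to compound 3 (beyond the scatter) at this position. Starting from 2-fluorophenyl, the same ring brings a number 38 percentage points lower from compound 1 to compound 3 (beyond the scatter) and so the lower number appears from either fluorophenyl group. No measurement at hand accounts for this loss of maximal response.

The compounds shown leave open whether the step comes from the ring nitrogen or from the missing fluorine, a question that plain phenyl on the same oxygen would help to separate. Also open, going by these compounds, is whether pyridin-2-yl or pyridin-4-yl would give a number like that of pyridin-3-yl or one closer to the fluorophenyl compounds.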